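Aryl swap on the shared core: compound 1 to compound 4

This account rests on a few compounds, and the source may have more. Where it says the series, first, only, none or still open, it means among the compounds named here.

Within the data shown here, compound 1 `COC(=O)C1=C(C)N=C(C)/C(=C(\O)OC)C1c1cc(Cl)cc(Cl)c1` gives 93.3 nM in a functional assay (muscle tissue) with Cavia porcellus as the target (on this read-out higher numbers stand for an effect only at larger amounts of compound and lower numbers for an effect already at smaller amounts), the second highest of the three numbers known. Compound 2 `COC(=O)C1=C(C)N=C(C)/C(=C(\O)OC)C1c1cccc(N)c1` gives 2000 nM and compound 3 `COC(=O)C1=C(C)N=C(C)/C(=C(\O)OC)C1c1ccccc1C#N` gives 15.9 nM in this assay. The step of a 21-fold higher number from compound 1 to compound 2 (1.33 log units; beyond the scatter) is large, the step of a 5.9-fold lower number from compound 1 to compound 3 (0.77 log units; beyond the scatter) is modest, and between those two compounds a 130-fold lower number from compound 2 to compound 3 (2.10 log units; beyond the scatter). Compound 4 `COC(=O)C1=C(C)N=C(C)/C(=C(\O)OC)C1c1cccc(Cl)c1Cl` differs from compound 1 by 2,3-dichlorophenyl in place of 3,5-dichlorophenyl on a saturated ring carbon. Among the measured compounds shown here, no measured step shifts the chlorines alone; the only step that keeps the phenyl free of new groups while altering its pattern is a 5.9-fold lower number from compound 1 to compound 3 (0.77 log units; beyond the scatter), whereas compound 2 shows that a changed pattern can also raise the number sharply. Compound 4 is therefore expected at 50 nM (range 15 nM to 200 nM), a step of a 1.9-fold lower number from compound 1 to compound 4 (0.27 log units; within the scatter) that is expected to stay small.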

Compound 4, half-maximal effective concentration: 19.1 nM
Compound 4: the middle estimate sits 2.6-fold (0.42 log units) above what was measured; the range from low to high includes it.
By their numbers in this assay, from the lowest: compounds 3 and 4 (each within the scatter of the next); then compound 1; then compound 2.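

Moving the chlorines alone, with the same atoms joined differently, is enough for a 4.9-fold lower number from compound 1 to compound 4 (0.69 log units; beyond the scatter) and so the read-out at this saturated ring carbon follows the arrangement on the phenyl, not just its atoms. The 2,3-dichlorophenyl and 2-cyanophenyl groups cannot be told apart, with a 1.2-fold higher number from compound 3 to compound 4 (0.08 log units; within the scatter) despite their different atoms, while a 100-fold lower number from compound 2 to compound 4 (2.02 log units; beyond the scatter) leaves 3-aminophenyl well separated from 2,3-dichlorophenyl. No evidence on the cause of these steps is available.

Which of the two chlorines of compound 4 carries the step from compound 1 remains open. A phenyl with a single chlorine or with a methoxy group would test this.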